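This account rests on a few compounds, and the source may have more. Where it says the series, first, only, none or still open, it means among the compounds named here.

Measured in an ADME assay on HepG2 cells (Homo sapiens) for cytotoxicity, in the presence of a further agent that is not named here; a higher number here means a weaker inhibitor, a lower number a stronger inhibitor:
Compound 1 `Cn1c(Cc2ccccc2C(F)(F)F)nc(C(=O)NCC2CCCCC2)c(O)c1=O`: > 100000 nM
Compound 2 `CC(NC(=O)c1nc(Cc2ccccc2C(F)(F)F)n(C)c(=O)c1O)c1ccccc1`: > 100000 nM

Compound 2 stands only at a limit of the assay, > 100000 nM. The same holds for the other measured compound, as the limit of > 100000 nM in this assay, at which 2 of the 2 values shown sit, shows. Compound 3 `Cn1c(Cc2ccccc2C(F)(F)F)nc(C(=O)NCc2ccccn2)c(O)c1=O` carries (pyridin-2-yl)methyl in place of 1-phenylethyl on an amide-type nitrogen. Among the measured compounds shown here, the one measured step at this nitrogen, a step that the two limits leave unreadable from compound 1 to compound 2, has no readable size and so offers no measure for the new change. No shift beyond the scatter is therefore expected in this assay, and the expected change is a number no higher from compound 2 to compound 3 (the limit leaves the size open). For compound 3 the estimated value is 100000 nM, with an expected range of 50000 nM to 200000 nM.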

Compound 3, half-maximal inhibitory concentration: > 100000 nM
Compound 3: only a limit was reported; the forecaster's own chance of this, stated with the estimate: 85%; the middle value lies on the limit itself.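

No step among compound 1, compound 2 and compound 3 can be read, because all three stand at one limit: the limit of > 100000 nM in this assay, at which 3 of the 3 values shown sit.

The compounds shown leave open whether any change on the amide-type nitrogen shifts the read-out in this assay.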